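Adding a propyl group to a weak chain compound

The compounds below may be only part of what the source reports. "The series", "measured", "known", "first", "only" and "open" are said of these compounds alone.

Values in a functional assay on SW480 cells (Homo sapiens) for antiproliferative activity, read by MTT assay, with a stated time of 48 h (a lower number here means a stronger inhibitor, a higher number a weaker inhibitor), are as follows
Compound 1 `CCC(CCO)n1cnc2c(Cl)nc(F)nc21` gives 19800 nM
Compound 2 `CCC(CCO)n1cnc2c(Cl)ncnc21` gives > 50000 nM as a limit

Compound 2 has no number, only the limit > 50000 nM of this test. The change to compound 3 `CCCCCC(CCO)n1cnc2c(Cl)ncnc21` is propyl in place of hydrogen on a saturated chain carbon, three bonds along the chain from an aromatic nitrogen and it puts propyl in place of hydrogen on a saturated chain carbon, three bonds along the chain from an aromatic nitrogen. For the measured compounds named here, the only measured step is an at least 2.5-fold higher number from compound 1 to compound 2 (0.40 log units; beyond the scatter) and it concerns hydrogen in place of fluoro on an aromatic carbon, not the chain. Going by the values given here, that step therefore bears only loosely on this change, and no measured step touches the chain. A modest move to a lower number in this assay is expected, though a second limit remains possible. Compound 3 is estimated at 28000 nM with 10000 nM to 50000 nM as its expected range. The expected change is an at least 1.7-fold lower number from compound 2 to compound 3 (0.25 log units; that floor lies within the scatter) as estimated here.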

Compound 3, half-maximal inhibitory concentration: > 50000 nM
Compound 3: a limit, no number; the forecaster's own chance of this, stated with the estimate: 40%; middle value at least 1.7-fold (0.25 log units) away from the limit.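

Compound 3, like compound 2, stands only as a limit in this assay, not as a number, so no step can be read from compound 2 to compound 3: the limit of > 50000 nM in this assay, at which 2 of the 3 values shown sit.

Whether propyl in place of hydrogen on this chain carbon changes the activity at all stays open in the compounds shown.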